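A few compounds are considered here, and "the series" means these few. Any claim that something is new, unique, unknown or untested is made for them only; others in the source may bear on it.

Measured compounds in a functional assay on HEK293 cells for agonist activity at Bile acid receptor (Homo sapiens), read by a luciferase reporter; on this read-out higher numbers stand for an effect only at larger amounts of compound and lower numbers for an effect already at smaller amounts:
- compound 1 `O=C(O)c1ccccc1OCc1ccc(OCc2c(-c3c(Cl)cccc3Cl)noc2C2CC2)nc1C(F)(F)F`: 611 nM
- compound 2 `O=C(O)c1ccc(OCc2ccc(OCc3c(-c4c(Cl)cccc4Cl)noc3C3CC3)nc2C(F)(F)F)cc1`: 38 nM
- compound 3 `CC(Oc1cccc(C(=O)O)c1)c1ccc(OCc2c(-c3c(Cl)cccc3Cl)noc2C2CC2)nc1C(F)(F)F`: 58 nM

Compound 3 stands second highest of the three numbers. Its nearest neighbour is compound 2, with a 1.5-fold higher number from compound 2 to compound 3 (0.18 log units; within the scatter); its furthest is compound 1, with an 11-fold lower number from compound 1 to compound 3 (1.02 log units; beyond the scatter).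

Compound 4 `CC(Oc1ccc(C(=O)O)cc1)c1ccc(OCc2c(-c3c(Cl)cccc3Cl)noc2C2CC2)nc1C(F)(F)F` is the next step: 4-carboxyphenyl in place of 3-carboxyphenyl on an oxygen on a saturated carbon.

Within the data shown here, three measured steps bear on it. The move of the carboxyl from the 2-position to the 4-position on the methylene-linked analogue gave a 16-fold lower number from compound 1 to compound 2 (1.21 log units; beyond the scatter). The move to 3-carboxyphenyl with the added methyl gave an 11-fold lower number from compound 1 to compound 3 (1.02 log units; beyond the scatter). Between compound 2 and compound 3, where both the carboxyl position and the linker change, the step is a 1.5-fold higher number from compound 2 to compound 3 (0.18 log units; within the scatter). Among the measured compounds shown here, no measured pair isolates 3-carboxyphenyl against 4-carboxyphenyl on the same ethyl link; the two low values of compound 2 and compound 3 suggest both arrangements are tolerated.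

The expected step is therefore a 1.5-fold lower number from compound 3 to compound 4 (0.16 log units; within the scatter), within the scatter. Compound 4 is estimated at 40 nM, with a range of 15 nM to 120 nM.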

Compound 4, half-maximal effective concentration: 611 nM
Estimate against measurement, compound 4: 15-fold (1.18 log units) below; the whole stated range lies below it.
By their numbers in this assay, from the lowest: compounds 2 and 3 (each within the scatter of the next); then compounds 1 and 4 (each within the scatter of the next).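

In this assay, among these compounds, the carboxyl position matters on the ethyl link: 4-carboxyphenyl in place of 3-carboxyphenyl on the oxygen gives an 11-fold higher number from compound 3 to compound 4 (1.02 log units; beyond the scatter), a comparison no earlier pair isolated. With 4-carboxyphenyl held fixed, methyl in place of hydrogen on the saturated chain carbon gives a 16-fold higher number from compound 2 to compound 4 (1.21 log units; beyond the scatter), and the result matches the 2-carboxyphenyl methylene-linked analogue, with no change at the digits printed from compound 1 to compound 4 (within the scatter). Nothing given here accounts for either large step.

Still open, on these data alone, is how 3-carboxyphenyl behaves on the methylene link, which would show whether the methyl affects that isomer as it does 4-carboxyphenyl. Also open, as far as these compounds go, is whether ethyl in place of that methyl, or a tetrazole in place of the carboxylic acid, would change the outcome on the 4-carboxyphenyl series.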